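A few compounds are considered here, and "the series" means these few. Any claim that something is new, unique, unknown or untested is made for them only; others in the source may bear on it.

Compound 1 `Cc1nc(S(C)(=O)=O)ccc1Oc1ncnc(OC2CCN(C(=O)OC3CCC3)CC2)c1F` sits in the middle of the three numbers from a functional assay on isolated protein for inhibition of Glucose-dependent insulinotropic receptor (Rattus norvegicus), read by HTRF and cAMP accumulation; a higher number here means that more compound is needed for the effect, a lower number that less compound is needed: compound 1 gives 167 nM, while compound 3 `Cc1nc(S(C)(=O)=O)ccc1Oc1ncnc(OC2CCN(C(=O)OC3(C(F)(F)F)CCC3)CC2)c1F` gives 63.3 nM and compound 2 `Cc1nc(S(C)(=O)=O)ccc1Oc1ncnc(OC2CCN(C(=O)OC3COC3)CC2)c1F` gives 2500 nM. Compound 4 `Cc1nc(S(C)(=O)=O)ccc1Oc1ncnc(OC2CCN(C(=O)SC3CC3)CC2)c1F` has not yet been measured. Relative to compound 1 the change is a group of 4 heavy atoms (3 carbon, 1 sulfur; one three-membered non-aromatic ring of carbon only) in place of a group of 5 heavy atoms (4 carbon, 1 oxygen; one four-membered non-aromatic ring of carbon only), on a carbonyl carbon. Two measured steps alter the same group on the carbonyl carbon: a 15-fold higher number from compound 1 to compound 2 (1.18 log units; beyond the scatter), and a 2.6-fold lower number from compound 1 to compound 3 (0.42 log units; beyond the scatter). Exchanging a ring of carbon only for another ring of carbon only, with sulfur in place of oxygen, resembles neither closely, so only a modest shift, most likely toward a higher number, is expected. For compound 4 the estimated value is 260 nM, between 80 nM and 850 nM, which is expected to be a 1.6-fold higher number from compound 1 to compound 4 (0.19 log units; within the scatter).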

Compound 4, half-maximal effective concentration: 126 nM
The estimate for compound 4 lay 2.1-fold (0.31 log units) above the measured number, within the range that was stated.
By their numbers in this assay, from the lowest: compounds 3, 4 and 1 (each within the scatter of the next, the first and the last beyond it); then compound 2.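

In this assay, a sulfur-linked three-membered carbon ring in place of cyclobutyloxy on the carbonyl carbon gives a 1.3-fold lower number from compound 1 to compound 4 (0.12 log units; within the scatter), so this position accepts both changes together without a shift beyond the scatter. The other comparisons show a 2.0-fold higher number from compound 3 to compound 4 (0.30 log units; within the scatter), and a 20-fold lower number from compound 2 to compound 4 (1.30 log units; beyond the scatter), leaving compound 2 well apart from the rest. No measurement here explains these steps. On these data alone, what the sulfur and the smaller ring each contribute alone remains open, as does the outcome of placing an amine or a carboxylic acid on that ring.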